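The source may report more compounds than this note shows. Statements on the series, on what has been measured and on what is new or still open speak of the compounds shown alone.

Compound 1 `CC(C)C(c1ccc(-c2ccc3cccc(F)c3c2)[nH]c1=O)C1SC(=O)NC1=O` was tested in a physicochemical assay for solubility, in phosphate buffer, measured as kinetic solubility (on this read-out higher numbers stand for higher solubility and lower numbers for lower solubility), and compound 1 gives 20100 nM. Compound 2 `CC(C)[C@H](C[C@@H]1OC(=O)NC1=O)c1ccc(-c2ccc3cccc(F)c3c2)[nH]c1=O` gives 21100 nM in this assay, so compound 1 stands at the lower of the two numbers, though that gap lies within the scatter and means no real difference. Compound 3 `CC(C)C(/C=C1\SC(=O)NC1=O)c1ccc(-c2ccc3cccc(F)c3c2)[nH]c1=O` has not been measured yet. It differs from compound 1 in one place: a group of 8 heavy atoms (4 carbon, 1 nitrogen, 2 oxygen, 1 sulfur; one five-membered non-aromatic ring with 2 hetero atoms) in place of a group of 7 heavy atoms (3 carbon, 1 nitrogen, 2 oxygen, 1 sulfur; one five-membered non-aromatic ring with 2 hetero atoms), on a saturated chain carbon bound to an aromatic carbon and a saturated chain carbon. A modest fall in solubility is expected, with the step from compound 1 to compound 3 estimated at a 2.2-fold lower number from compound 1 to compound 3 (0.35 log units; beyond the scatter). Compound 3 is therefore expected to give about 9000 nM, between 3000 nM and 25000 nM.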

Compound 3, solubility: 25600 nM
The estimate for compound 3 lay 2.8-fold (0.45 log units) below the measured number, and the stated range ends below it.
By their numbers in this assay, from the lowest: compounds 1, 2 and 3 (each within the scatter of the next).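

In this assay, placing the group of 8 heavy atoms, with its extra double bond outside aromatic rings, on this saturated chain carbon in place of the 2,4-dioxo-1,3-thiazolidin-5-yl group gives a 1.3-fold higher number from compound 1 to compound 3 (0.11 log units; within the scatter), so the two compounds cannot be told apart on this read-out. At this position, then, the change leaves the number within the usual scatter. Nothing measured here offers a reason for this result. Still open, on these data alone, is whether a different group on this carbon, such as a carboxylic acid or an amine, would move the number beyond the scatter.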